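The source may hold more compounds than are shown below. What is called first, only, known or untested is meant among the compounds shown, and "the series" means these compounds.

In a functional assay on MCF7 cells (Homo sapiens) for inhibition, read by MTT assay, with a stated time of 72 h (a higher number here means a weaker inhibitor, a lower number a stronger inhibitor), compound 1 `C=CCc1ccc(OCc2c(Cl)cccc2Cl)c(-c2ccc(OCc3c(Cl)cccc3Cl)c(CC=C)c2)c1` gives > 50000 nM, which is a limit and not a number. Two related compounds do return numbers: compound 2 `C=CCc1ccc(O)c(-c2ccc(OCc3ccccc3)c(CC=C)c2)c1` gives 23200 nM and compound 3 `C=CCc1ccc(O)c(-c2ccc(OCc3c(Cl)cccc3Cl)c(CC=C)c2)c1` gives 11500 nM.

Compound 4 `C=CCc1ccc(OCc2c(Cl)cccc2Cl)c(-c2ccc(O)c(CC=C)c2)c1` departs from compound 1 in one place: hydrogen in place of 2,6-dichlorobenzyl on an oxygen on an aromatic ring. In words, hydrogen stands in place of 2,6-dichlorobenzyl on an oxygen on an aromatic ring, so (2,6-dichlorobenzyl)oxy becomes hydroxy.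

The measured step closest to this is an at least 4.3-fold lower number from compound 1 to compound 3 (0.63 log units; beyond the scatter), the same exchange made at the other ether oxygen. That step starts from a limit, so it gives only a lower bound on its size, and the exchange at this particular oxygen has not been measured. A second step, a 2.0-fold lower number from compound 2 to compound 3 (0.30 log units; within the scatter), concerns 2,6-dichlorophenyl in place of phenyl on the benzyl group that remains, and it bears on the present change only indirectly.

Within the data shown here, a step toward a lower number, of a size like the one seen for compound 3 at 11500 nM, therefore seems the fair expectation. The expected step is an at least 4.1-fold lower number from compound 1 to compound 4 (0.61 log units; beyond the scatter). For compound 4 the estimated value is 12000 nM, with an expected range from 5000 nM to 30000 nM.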

Compound 4, half-maximal inhibitory concentration: 19400 nM
Compound 4: the middle estimate sits 1.6-fold (0.21 log units) below what was measured; the range from low to high includes it.
By their numbers in this assay, from the lowest: compounds 3, 4 and 2 (each within the scatter of the next). At a limit, above all of these: compound 1.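

In this assay, the exchange of (2,6-dichlorobenzyl)oxy for hydroxy at this oxygen is now measured directly, and it gives an at least 2.5-fold lower number from compound 1 to compound 4 (0.41 log units; beyond the scatter) at this position, where earlier only the other ether oxygen had been tested. The direction matches the step seen at that other oxygen, so among the compounds shown, losing either 2,6-dichlorobenzyl group moves the result from a limit to a number, and no compound here goes against this. Compound 1 gives only a limit, so the step sets a lower bound on the size of the exchange and not its full size: the limit of > 50000 nM in this assay, at which 1 of the 4 values shown sits.

The compounds shown leave open whether the hydroxy group itself matters at this place or whether removing the 2,6-dichlorobenzyl group is enough, a question that a methoxy group or an amine on the same ring position would address. They also leave open what a hydroxy group at both ether oxygens would give, and how large the exchange truly is when it starts from a number and not from a limit.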